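Fluoro for methyl on the sulfonyl aryl group

This account rests on a few compounds, and the source may have more. Where it says the series, first, only, none or still open, it means among the compounds named here.

Values measured in a functional assay on SMMC-7721 cells (Homo sapiens) for cytotoxicity, read by MTT assay, with a stated time of 24 h (a higher number here means a weaker inhibitor, a lower number a stronger inhibitor), are as follows.
- compound 1 `O=C1/C(=C/c2cccnc2)CN(S(=O)(=O)c2ccc(F)cc2)C/C1=C\c1ccccc1F` gives 9900 nM
- compound 2 `O=C1/C(=C/c2ccncc2)CN(S(=O)(=O)c2ccccc2)C/C1=C\c1ccccc1F` gives 17500 nM
- compound 3 `Cc1ccc(S(=O)(=O)N2C/C(=C\c3ccncc3)C(=O)/C(=C/c3ccccc3F)C2)cc1` gives 13200 nM

Compound 3 gives 13200 nM in this assay and lies within the scatter of both compound 1 and compound 2. The next structure is compound 4 `O=C1/C(=C/c2ccncc2)CN(S(=O)(=O)c2ccc(F)cc2)C/C1=C\c1ccccc1F`, not yet measured. The change is fluoro in place of methyl on an aromatic carbon and amounts to fluoro in place of methyl on an aromatic carbon, turning (4-methylphenyl)sulfonyl into (4-fluorophenyl)sulfonyl.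

Going by the values given here, no measured step covers this exchange directly. The nearest evidence is a 1.3-fold lower number from compound 2 to compound 3 (0.12 log units; within the scatter) for methyl in place of hydrogen on an aromatic carbon, a step that stays within the scatter. Compound 1 also carries the (4-fluorophenyl)sulfonyl group and differs from compound 4 elsewhere in the structure. In this assay compound 1 gives 9900 nM as a further reference. On this basis, no change beyond the scatter is expected in this assay, and no direction can be called with confidence. The expected step is a 1.1-fold lower number from compound 3 to compound 4 (0.04 log units; within the scatter) and is not expected to exceed the scatter. The estimate for compound 4 is 12000 nM (range 6500 nM to 22000 nM).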

Compound 4, half-maximal inhibitory concentration: > 20000 nM
Compound 4: no number, only a limit; the forecaster's own chance of this, stated with the estimate: 3%; middle value at least 1.6-fold (0.22 log units) away from the limit.
By their numbers in this assay, from the lowest: compounds 1, 3 and 2 (each within the scatter of the next). At a limit, above all of these: compound 4.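

In this assay compound 4 yields only a limit of the assay, not a number: the limit of > 20000 nM in this assay, at which 1 of the 4 values shown sits. Going by these compounds, at this aromatic carbon, para to a large group, the exchange of methyl for fluoro gives an at least 1.5-fold higher number from compound 3 to compound 4 (0.18 log units; that floor lies within the scatter), and fluoro in place of hydrogen gives an at least 1.1-fold higher number from compound 2 to compound 4 (0.05 log units; that floor lies within the scatter); both are floors, so the real size of each step stays unknown, whereas the earlier methyl for hydrogen step, a 1.3-fold lower number from compound 2 to compound 3 (0.12 log units; within the scatter), had a measured size. The change of pyridin-3-yl to pyridin-4-yl with the (4-fluorophenyl)sulfonyl group held fixed gives an at least 2.0-fold higher number from compound 1 to compound 4 (0.30 log units; that floor lies within the scatter), also only a floor, so the series now holds a pair in which one member has a number and the other only a limit, yet no step from compound 4 is shown to go beyond the scatter.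

A measured number for compound 4 would settle which of these steps, if any, is real. Also open, on these data alone, is how an amine, a carboxylic acid or a longer chain on the same aromatic carbon would read in this assay.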